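A few compounds are considered here, and "the series" means these few. Any claim that something is new, unique, unknown or untested is made for them only; others in the source may bear on it.

Measured compounds:
- compound 1 `Cc1cccc(-c2nc(C)c(COc3ccc4c(c3)OCC4CC(=O)O)s2)c1`: 47.2%
- compound 2 `Cc1nc(-c2ccccc2F)sc1COc1ccc2c(c1)OCC2CC(=O)O`: 25.8%
- compound 3 `Cc1nc(-c2ccc(F)cc2)sc1COc1ccc2c(c1)OCC2CC(=O)O`: 61.6%

All three share one core and differ only in the aryl group on the five-membered ring. In a functional assay on CHO cells for agonist activity at Free fatty acid receptor 1 (Homo sapiens), read by FLIPR and calcium flux, tested at 100 nM (a lower number here means a weaker effect, a higher number a stronger effect of the compound at the concentration tested), compound 3 gives 61.6%, the highest of the three numbers, the steps to compound 1 and to compound 2 both lying beyond the scatter. The step of a number 14.4 percentage points higher from compound 1 to compound 3 (beyond the scatter) is modest, the step of a number 21.4 percentage points lower from compound 1 to compound 2 (beyond the scatter) is modest in the other direction, and the step of a number 35.8 percentage points higher from compound 2 to compound 3 (beyond the scatter) is large.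

Compound 4 `Cc1nc(-c2ccccc2C(F)(F)F)sc1COc1ccc2c(c1)OCC2CC(=O)O` is not yet measured. It differs from compound 3 as follows: 2-(trifluoromethyl)phenyl in place of 4-fluorophenyl on an aromatic carbon. Among the measured compounds shown here, the step that bears on this change is the one between compound 2, which carries 2-fluorophenyl, and compound 3, which carries 4-fluorophenyl, and that step was large. Compound 4 again carries a 2-substituted phenyl, so a fall in this assay is expected, of the order of a number 36.6 percentage points lower from compound 3 to compound 4 (beyond the scatter). Compound 4 is therefore estimated at 25%, with a range from 5% to 50%.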

Compound 4, a percentage reported as activity, at one concentration (the size of the read-out at that concentration, not a potency): 7.76%
The estimate for compound 4 lay 17.2 percentage points above the measured number; measured number inside the range.
By their numbers in this assay, from the lowest: compound 4; then compound 2; then compound 1; then compound 3.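

In this assay, the 2-(trifluoromethyl)phenyl group gives a number 53.8 percentage points lower from compound 3 to compound 4 (beyond the scatter) and a number 39.4 percentage points lower from compound 1 to compound 4 (beyond the scatter), so the low read-out of the 2-fluorophenyl compound is no longer a single case: both 2-substituted phenyl compounds now sit at the bottom of the series. Among these two, trifluoromethyl in place of fluoro gives a number 18 percentage points lower from compound 2 to compound 4 (beyond the scatter), so the read-out depends on the identity of the substituent as well as on its place on the phenyl ring. Nothing available explains this fall.

Compound 3 and compound 4 differ in both the substituent and its place, so a 4-(trifluoromethyl)phenyl group would be needed to separate the two. On these data alone, whether a 2-methoxyphenyl or 2-methylphenyl group follows the same trend also remains open, and a read-out at one concentration does not give potency.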